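Compound 3 to compound 4: hydroxy replaces bromo

A few compounds are considered here, and "the series" means these few. Any claim that something is new, unique, unknown or untested is made for them only; others in the source may bear on it.

Measured so far in a functional assay on COLO 205 cells (Homo sapiens) for cytotoxicity, read by MTT assay, with a stated time of 48 h; a higher number here means a weaker inhibitor, a lower number a stronger inhibitor:

Compound 1 `Fc1cccc(-c2nc(Nc3ccccc3)c3cc(F)ccc3n2)c1`: 49700 nM
Compound 2 `COc1ccc(Nc2nc(-c3cccc(F)c3)nc3ccc(F)cc23)cc1`: 46800 nM
Compound 3 `Fc1cccc(-c2nc(Nc3ccc(Br)cc3)c3cc(F)ccc3n2)c1`: > 50000 nM (a limit)

Compound 3 has no number, only a limit, (the limit of > 50000 nM in this assay, at which 1 of the 3 values shown sits). Compound 4 `Oc1ccc(Nc2nc(-c3cccc(F)c3)nc3ccc(F)cc23)cc1` differs from it as follows: hydroxy in place of bromo on an aromatic carbon. In words, hydroxy stands in place of bromo on an aromatic carbon, para to a large group. Three measured steps changed that same place. They are a 1.1-fold lower number from compound 1 to compound 2 (0.03 log units; within the scatter), a number no lower from compound 1 to compound 3 (the limit leaves the size open) and an at least 1.0-fold higher number from compound 2 to compound 3 (0.02 log units; that floor lies within the scatter). None shows a change beyond the scatter, so only a modest shift is expected in this assay, towards a lower number if any. The expected step is an at least 1.2-fold lower number from compound 3 to compound 4 (0.09 log units; that floor lies within the scatter). Compound 4 is estimated at 40000 nM, with an expected range of 15000 nM to 50000 nM.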

Compound 4, half-maximal inhibitory concentration: > 50000 nM
Compound 4 gave a limit, no number; the forecaster's own chance of this, stated with the estimate: 30%; middle value at least 1.2-fold (0.09 log units) from the limit.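

In this assay, the hydroxy group of compound 4, with a hydrogen-bond donor and acceptor that bromo lacks, gives only a limit, as bromo does in compound 3, which leaves a step that the two limits leave unreadable from compound 3 to compound 4: the limit of > 50000 nM in this assay, at which 2 of the 4 values shown sit. Against the methoxy group, the printed step is an at least 1.0-fold higher number from compound 2 to compound 4 (0.02 log units; that floor lies within the scatter), so hydrogen in place of methyl on the oxygen establishes no change beyond the scatter. Against hydrogen, the printed step is a number no lower from compound 1 to compound 4 (the limit leaves the size open), and it cannot be read either.

On these data alone, whether an amine or a carboxylic acid at this place would give a clearly lower number stays open. So does how far compound 3 and compound 4 lie beyond their limits.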